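The compounds below may be only part of what the source reports. "The series", "measured", "known", "first", "only" and "open" are said of these compounds alone.

Compound 1: `O=C(CN1CCN(c2nnc(Cc3ccncc3)c3ccccc23)CC1)Nc1ccc(F)c(F)c1` gives 2320 nM in a functional assay on HT-29 cells (Homo sapiens) for cytotoxicity, read by MTT assay, with a stated time of 72 h; a higher number here means a weaker inhibitor, a lower number a stronger inhibitor.
Compound 2: `O=C(CN1CCN(c2nnc(Cc3ccncc3)c3ccccc23)CC1)Nc1ccc(F)c(Cl)c1` gives 880 nM in this assay.
Compound 3: `O=C(CN1CCN(c2nnc(Cc3ccncc3)c3ccccc23)CC1)Nc1cccc(F)c1` gives 6130 nM in this assay.

Compound 3 stands with the highest number of the three; compound 1 is nearest to it and compound 2 furthest, both steps beyond the scatter. Compound 4 is `O=C(CN1CCN(c2nnc(Cc3ccncc3)c3ccccc23)CC1)Nc1ccc(Br)cc1`, and the change from compound 3 is 4-bromophenyl in place of 3-fluorophenyl on an amide-type nitrogen. Going by the values given here, two measured steps bear on it. Taking fluoro off the ring of compound 1 gave a 2.6-fold higher number from compound 1 to compound 3 (0.42 log units; beyond the scatter), so a halogen on the 3-fluorophenyl partner of compound 3 may be missed. Putting chloro in place of fluoro gave a 2.6-fold lower number from compound 1 to compound 2 (0.42 log units; beyond the scatter), and the whole swap of that anilide ring gave a 7.0-fold higher number from compound 2 to compound 3 (0.84 log units; beyond the scatter). Compound 4 returns a halogen to the ring, as bromo, while losing the fluoro of compound 3, so a lower number is expected, of modest size. The expected step is a 3.1-fold lower number from compound 3 to compound 4 (0.49 log units; beyond the scatter). Compound 4 is therefore estimated at 2000 nM, with a range from 600 nM to 6500 nM.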

Compound 4, half-maximal inhibitory concentration: 1990 nM
Compound 4: the middle estimate sits 1.0-fold (0.00 log units) above what was measured; low and high end bracket the measured number.
By their numbers in this assay, from the lowest: compound 2; then compounds 4 and 1 (each within the scatter of the next); then compound 3.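

Compound 4 shows that a second halogen on the ring is not needed for a lower number in this assay, since 4-bromophenyl in place of 3-fluorophenyl on the amide-type nitrogen gives a 3.1-fold lower number from compound 3 to compound 4 (0.49 log units; beyond the scatter). Set against 3,4-difluorophenyl, the same group gives a 1.2-fold lower number from compound 1 to compound 4 (0.07 log units; within the scatter), so these two rings stand level in this assay. The 3-chloro-4-fluorophenyl ring remains ahead of 4-bromophenyl, with a 2.3-fold higher number from compound 2 to compound 4 (0.35 log units; beyond the scatter).

Because the halogen and its place on the ring change together in compound 4, the compounds shown leave open which of the two carries the step, and whether a methoxy group or an amine on the ring would hold the number. No evidence is available on why these rings differ.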